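The source may hold more compounds than are shown below. What is called first, only, known or untested is meant among the compounds shown, and "the series" means these compounds.

Of the compounds shown here, three sharing one core have been tested in a functional assay on A549 cells (Homo sapiens) for antiproliferative activity, read by MTT assay, with a stated time of 48 h (on this read-out lower numbers stand for stronger inhibition and higher numbers for weaker inhibition), and they differ only in the aryl group on an aromatic nitrogen. Compound 1 (`C/C(=C\CC/C(C)=C/CC[C@@H]1[C@@]2(C)CCC(=O)C(C)(C)[C@H]2CC[C@@]1(C)O)CC/C=C(\C)C(=O)OCc1cn(-c2ccc(C(F)(F)F)cc2)nn1`) gives > 150000 nM, which is a limit and not a number. Compound 2 (`C/C(=C\CC/C(C)=C/CC[C@@H]1[C@@]2(C)CCC(=O)C(C)(C)[C@H]2CC[C@@]1(C)O)CC/C=C(\C)C(=O)OCc1cn(-c2ccccc2C(F)(F)F)nn1`) gives > 150000 nM, again a limit. Compound 3 (`C/C(=C\CC/C(C)=C/CC[C@@H]1[C@@]2(C)CCC(=O)C(C)(C)[C@H]2CC[C@@]1(C)O)CC/C=C(\C)C(=O)OCc1cn(-c2ccccc2Br)nn1`) gives > 150000 nM, also a limit, so it has no measured number to start from. Going by the values given here, the series so far stands at the limit of > 150000 nM in this assay, at which 3 of the 3 values shown sit.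

Among the compounds with values here, compound 4 (`C/C(=C\CC/C(C)=C/CC[C@@H]1[C@@]2(C)CCC(=O)C(C)(C)[C@H]2CC[C@@]1(C)O)CC/C=C(\C)C(=O)OCc1cn(-c2ccc(F)c(Cl)c2)nn1`) keeps the core and changes only this aryl group: 3-chloro-4-fluorophenyl in place of 2-bromophenyl on an aromatic nitrogen. In words, 3-chloro-4-fluorophenyl comes in place of 2-bromophenyl on an aromatic nitrogen of a five-membered aromatic ring with 3 nitrogen.

The measured steps that bear on this change are a step that the two limits leave unreadable from compound 1 to compound 3, a step that the two limits leave unreadable from compound 2 to compound 3 and a step that the two limits leave unreadable from compound 1 to compound 2. None of them has a readable size, so they give no direction for a further exchange of aryl groups in this assay. No step beyond the scatter is therefore expected, and compound 4 is expected to stay close to the same limit, quite possibly reported only as a limit.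

For compound 4 the expected value is 130000 nM, with an estimated range from 40000 nM to 220000 nM. The estimate means an expected at least 1.1-fold lower number from compound 3 to compound 4 (0.06 log units; that floor lies within the scatter).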

Compound 4, half-maximal inhibitory concentration: > 150000 nM
Compound 4: no number, only a limit (the forecaster's own chance of this, stated with the estimate: 70%); middle value at least 1.1-fold (0.06 log units) away from the limit.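

In this assay compound 4 gives > 150000 nM, which is a limit and not a number. Going by these compounds alone, no step from compound 1, compound 2 or compound 3 to compound 4 can be read, and the series stays where it stood: the limit of > 150000 nM in this assay, at which 4 of the 4 values shown sit. The compounds shown leave open whether any aryl group on this aromatic nitrogen gives a measured number at all, and how far these aryl groups differ.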